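The compounds below may be only part of what the source reports. "The series", "measured", "known", "first", "only" and "open" are said of these compounds alone.

Compounds measured so far:

compound 1, `CCC(O)CSc1nc(NCc2ccc(-c3ccccn3)cc2)c2[nH]nc(C(C)C)c2n1`: 273 nM
compound 2, `CC(C)c1n[nH]c2c(NCc3ccc(-c4ccccn4)cc3)nc(SC3CCCCC3O)nc12`: 636 nM
compound 3, `CC(C)c1n[nH]c2c(NCc3ccc(-c4ccccn4)cc3)nc(SCC(O)CN3CCNCC3)nc12`: 332 nM

All three share a core and differ only in the group carried on the sulfur. In a functional assay on HT cells (Homo sapiens) for antiproliferative activity, read by fluorescence, with a stated time of 72 h (on this read-out lower numbers stand for stronger inhibition of growth and higher numbers for weaker inhibition of growth), compound 3 gives 332 nM. It stands second highest of the three numbers: a 1.2-fold higher number from compound 1 to compound 3 (0.08 log units; within the scatter), and a 1.9-fold lower number from compound 2 to compound 3 (0.28 log units; within the scatter).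

Compound 4, `CC(C)c1n[nH]c2c(NCc3ccc(-c4ccccn4)cc3)nc(SCC(C)(C)N)nc12`, has not been measured. Its change from compound 3 is 1-amino-1-methylethyl in place of 1-hydroxy-2-(piperazin-1-yl)ethyl on a saturated chain carbon bound to a sulfur; cut one bond further out, this reads 2-hydroxy-3-(piperazin-1-yl)propyl to 2-amino-2-methylpropyl on the sulfur.

Going by the values given here, two measured steps bear on this. The step of a 1.2-fold higher number from compound 1 to compound 3 (0.08 log units; within the scatter) shows that swapping piperazin-1-yl for methyl at the chain end leaves the number within the scatter. The step of a 2.3-fold higher number from compound 1 to compound 2 (0.37 log units; beyond the scatter) shows that a larger reshaping of the sulfur substituent moves the number only modestly. Taken together, the three numbers sit within a narrow band, and the change to compound 4 is no larger than those already seen.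

Compound 4 is therefore expected to fall near compound 3, with a 1.1-fold higher number from compound 3 to compound 4 (0.04 log units; within the scatter) not beyond the scatter. The estimate for compound 4 in this assay is 360 nM, with a range from 150 nM to 900 nM.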

Compound 4, concentration for 50% growth inhibition: 85 nM
For compound 4 the middle estimate is 4.2-fold (0.63 log units) above the measured one; measured number outside the range, below it.
By their numbers in this assay, from the lowest: compound 4; then compounds 1, 3 and 2 (each within the scatter of the next, the first and the last beyond it).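

In this assay, the change on the sulfur to 2-amino-2-methylpropyl gives the first clear separation in this set: compound 4 lies beyond the scatter of every other compound shown (a 3.9-fold lower number from compound 3 to compound 4 (0.59 log units; beyond the scatter); a 3.2-fold lower number from compound 1 to compound 4 (0.51 log units; beyond the scatter); a 7.5-fold lower number from compound 2 to compound 4 (0.87 log units; beyond the scatter)). The earlier compounds shown here, all of which carry a hydroxyl on the sulfur substituent, had left only compound 1 and compound 2 apart, so this position can move the number further than they suggested, and with a smaller group than the 2-hydroxy-3-(piperazin-1-yl)propyl of compound 3. No measurement here accounts for the drop in the number.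

Compound 4 differs from each of the others in several features at once, since it gains a primary amine, gains branching on the carbon that holds it and has no hydroxyl, so the compounds shown do not separate these contributions. The open comparisons are a plain 2-aminoethyl on the sulfur, which would test the amine without the branching methyl groups, and a 2-hydroxy-2-methylpropyl, which would test the branching with a hydroxyl in place of the amine.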